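The source may report more compounds than this note shows. Statements on the series, on what has been measured and on what is new or still open speak of the compounds shown alone.

Compound 1, `COc1ccc(-c2ccnc(Nc3ccc4c(c3)c(/C=C3/C(=O)Nc5ccccc53)cn4C)n2)cc1`, gives in a functional assay on LNCaP cells (Homo sapiens) for cytotoxicity, read by MTT assay, with a stated time of 48 h (on this read-out lower numbers stand for stronger inhibition and higher numbers for weaker inhibition), only a limit of the assay: > 100000 nM.
Compound 2, `Cn1cc(/C=C2/C(=O)Nc3ccccc32)c2cc(Nc3nccc(-c4ccc(F)cc4)n3)ccc21`, gives in this assay 16300 nM.

Going by the values given here, compound 2 thus holds the only number among the two values shown in this assay; the other value, that of compound 1, is a limit, and the limit is the one at the limit of > 100000 nM in this assay, at which 1 of the 2 values shown sits. Among the compounds with values here, the single measured step, an at least 6.1-fold lower number from compound 1 to compound 2 (0.78 log units; beyond the scatter), runs into compound 2 from a compound that reached only that limit, so its true size is known only as a lower bound.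

Compound 3, `Cn1cc(/C=C2/C(=O)Nc3ccccc32)c2cc(Nc3nccc(-c4ccc(C(F)(F)F)cc4)n3)ccc21`, differs from compound 2 by trifluoromethyl in place of fluoro on an aromatic carbon. This change sits at the same place as the measured step, but it exchanges one halogen-bearing group for another rather than removing methoxy, so that step bears on it only loosely. Nothing in the two values shown points to a particular direction. Compound 3 is therefore expected to give 14000 nM, with a range of 4000 nM to 50000 nM, an expected step of a 1.2-fold lower number from compound 2 to compound 3 (0.07 log units; within the scatter) that stays close to the scatter.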

Compound 3, half-maximal inhibitory concentration: > 100000 nM
Compound 3: no number, only a limit; the forecaster's own chance of this, stated with the estimate: 12%; at least 7.1-fold (0.85 log units) between middle value and limit.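

The exchange of one fluorine-bearing group for another is not neutral at this place, para to a large group: in this assay, trifluoromethyl in place of fluoro gives an at least 6.1-fold higher number from compound 2 to compound 3 (0.78 log units; beyond the scatter). The earlier step alone left open that methoxy was a particular liability, but the 4-(trifluoromethyl)phenyl of compound 3 now also ends at a limit of the assay, so a readable value no longer depends only on methoxy being absent, and of the three groups shown at this place, only fluoro gives a number, while methoxy and trifluoromethyl both stop at the same limit: the limit of > 100000 nM in this assay, at which 2 of the 3 values shown sit. The step between compound 1 and compound 3 cannot be read, as both values are limits, so these two groups cannot be ordered.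

The compounds shown leave open whether any other group at this place, such as chloro, an amine or a carboxylic acid, would give a number, and how that number would stand against compound 2 at 16300 nM. The three values also cannot say which feature sets fluoro apart from methoxy and trifluoromethyl.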